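The source may hold more compounds than are shown below. What is called first, only, known or untested is meant among the compounds shown, and "the series" means these compounds.

Working notes on the series built around the shared core of compound 1 `CC(C)N(Cc1cccc(OCCCCCC(=O)O)c1)C(=O)c1ccc(-c2ccncc2)cc1`. In an ADME assay on HepG2 cells (Homo sapiens) for cytotoxicity, read by CellTiter-Glo and resazurin assay, with a stated time of 72 h (on this read-out higher numbers stand for an effect only at larger amounts of compound and lower numbers for an effect already at smaller amounts), compound 1 gives a value that is a limit of the assay, > 26000 nM. Compound 2 `CC(C)N(Cc1cccc(OCCCCCC(=O)O)c1)C(=O)c1ccc(-c2ccco2)cc1` carries furan-2-yl in place of pyridin-4-yl on an aromatic carbon; in this assay compound 2 likewise returns only the limit > 26000 nM. Compound 3 `CCOC(=O)CCCCCOc1cccc(CN(C(=O)c2ccc(-c3ccncc3)cc2)C(C)C)c1` has ethyl in place of hydrogen on an oxygen next to a carbonyl group; in this assay compound 3 also sits at the limit, > 26000 nM. The two steps a step that the two limits leave unreadable from compound 1 to compound 2 and a step that the two limits leave unreadable from compound 1 to compound 3 cannot be read in size because every value shown sits at the limit of > 26000 nM in this assay, at which 3 of the 3 values shown sit. Compound 3 therefore stands where the whole set stands: at the limit, with no number.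

Compound 4 `CCOC(=O)CCCCCOc1cccc(CN(C(=O)c2ccc(-c3cc(F)cc(OC)c3)cc2)C(C)C)c1` is not yet measured; it differs from compound 3 by 3-fluoro-5-methoxyphenyl in place of pyridin-4-yl on an aromatic carbon. Going by the values given here, no measured step bears on this change at a readable size. The step from compound 3 to compound 4 is expected to be a step that the limit leaves unreadable from compound 3 to compound 4, nothing the scatter could separate. For compound 4 the expected value in this assay is 40000 nM, within a range from 15000 nM to 100000 nM, most likely again returned only as a limit.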

Compound 4, half-maximal effective concentration: > 26000 nM
Compound 4: a limit, no number; the forecaster's own chance of this, stated with the estimate: 75%; the middle value lies beyond the limit too.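

The step from compound 3 to compound 4 cannot be read in size in this assay because both values are limits, not numbers: the limit of > 26000 nM in this assay, at which 4 of the 4 values shown sit.

The compounds shown leave open at what concentration any of them takes effect, and whether pyridin-4-yl, furan-2-yl and 3-fluoro-5-methoxyphenyl differ at all.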